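A few compounds are considered here, and "the series" means these few. Any claim that something is new, unique, unknown or untested is made for them only; others in the source may bear on it.

Compound 1 `O=C(CCl)Nc1ccc(C(=O)/C=C/c2ccccc2)cc1` and compound 2 `O=C(CCl)Nc1ccc(C(=O)/C=C/c2ccc(Br)cc2)cc1` share one core, while compound 3 `O=C(CSC(=S)N[C@H]1CCOC1=O)Nc1ccc(C(=O)/C=C/c2ccccc2)cc1` and compound 4 `O=C(CSC(=S)N[C@H]1CCOC1=O)Nc1ccc(C(=O)/C=C/c2ccc(Br)cc2)cc1` share another. The two cores differ by a group of 10 heavy atoms (5 carbon, 1 nitrogen, 2 oxygen, 2 sulfur; one five-membered non-aromatic ring with 1 hetero atom) in place of one chlorine atom, on a saturated chain carbon bound to a carbonyl carbon, a change that gave a 7.0-fold higher number from compound 1 to compound 3 (0.85 log units; beyond the scatter) in a functional assay on EC9706 cells (Homo sapiens) for cytotoxicity, read by MTT assay, with a stated time of 72 h; a higher number here means a weaker inhibitor, a lower number a stronger inhibitor. On the first core, compound 1 gives 6370 nM and compound 2 gives 10100 nM; the change between them is bromo in place of hydrogen on an aromatic carbon, and the step was a 1.6-fold higher number from compound 1 to compound 2 (0.20 log units; within the scatter). Compound 3 gives 44900 nM, the highest number among the three measured compounds. Compound 4 carries the same change on the second core, namely (bromo in place of hydrogen on an aromatic carbon). Because that change gave only a 1.6-fold higher number from compound 1 to compound 2 (0.20 log units; within the scatter) on the first core, compound 4 is expected to show a similarly small step of a 1.3-fold higher number from compound 3 to compound 4 (0.13 log units; within the scatter). Compound 4 is therefore estimated at 60000 nM, with a range from 25000 nM to 150000 nM.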

Compound 4, half-maximal inhibitory concentration: 91200 nM
Beside the measured number, compound 4's estimate is 1.5-fold (0.18 log units) below it; the measured number falls inside the stated range.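

In this assay bromo in place of hydrogen on the aromatic carbon gave a 2.0-fold higher number from compound 3 to compound 4 (0.31 log units; beyond the scatter) and matched the step on the core of compound 1: the same change on two cores in this assay, a 1.6-fold higher number (0.20 log units; within the scatter) from compound 1 to compound 2 and a 2.0-fold higher number (0.31 log units; beyond the scatter) from compound 3 to compound 4, 1.3-fold (0.11 log units) apart, within the scatter of two such steps. Replacing the chlorine atom with the group of 10 heavy atoms gave a 9.0-fold higher number from compound 2 to compound 4 (0.96 log units; beyond the scatter) and also carried over between the phenyl and 4-bromophenyl compounds: the same change on two cores in this assay, a 7.0-fold higher number (0.85 log units; beyond the scatter) from compound 1 to compound 3 and a 9.0-fold higher number (0.96 log units; beyond the scatter) from compound 2 to compound 4, 1.3-fold (0.11 log units) apart, within the scatter of two such steps. Both changes thus kept their size across this single pair of cores, but four compounds do not show that they would do so on any other core, nor do they explain why the numbers rise.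

The compounds shown leave open whether chloro or methoxy on that aromatic carbon would follow the bromo step. They also leave open how an amine or a carboxylic acid in place of the chlorine atom would compare.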